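The compounds below may be only part of what the source reports. "The series", "measured", "known", "first", "only" and "open" are said of these compounds alone.

Measured so far:
- Compound 1 `CN1CCCN(CCNc2nccc(-c3c(-c4cccc(O)c4)nc4sccn34)n2)S1(=O)=O`: 11900 nM
- Compound 2 `O=S(=O)(NCCCNc1nccc(-c2c(-c3cccc(O)c3)nc3sccn23)n1)c1cccc(F)c1`: 2410 nM

In a functional assay on cells (Panel breast (Carcinoma cell lines), Homo sapiens) for inhibition, read by sulforhodamine B assay, with a stated time of 48 h (a lower number here means a stronger inhibitor, a higher number a weaker inhibitor), compound 2 gives the lower of the two numbers, 2410 nM, which makes it the stronger inhibitor of the pair. The next compound to be measured is compound 3 `O=S(=O)(NCCNc1nccc(-c2c(-c3cccc(O)c3)nc3sccn23)n1)c1ccc(F)cc1`. Its change from compound 2 is ((4-fluorophenyl)sulfonyl)amino in place of (((3-fluorophenyl)sulfonyl)amino)methyl on a saturated chain carbon, two bonds along the chain from a nitrogen on an aromatic ring. Both groups hold a six-membered aromatic ring of carbon only, and both carry a fluorine.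

For the measured compounds named here, only one measured step exists, a 4.9-fold lower number from compound 1 to compound 2 (0.69 log units; beyond the scatter). It brought in the aromatic ring in place of a six-membered non-aromatic ring, a modest gain that compound 3 is expected to keep. Going by the values given here, no measured pair isolates the present change, so no step beyond the scatter is expected in this assay, and no direction can be favoured with confidence. The expected step is a 1.2-fold higher number from compound 2 to compound 3 (0.07 log units; within the scatter). For compound 3 the estimated value is 2800 nM, with an expected range from 1000 nM to 8000 nM.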

Compound 3, half-maximal inhibitory concentration: 4100 nM
For compound 3 the middle estimate is 1.5-fold (0.17 log units) below the measured one, and the stated range covers the measured number.
By their numbers in this assay, from the lowest: compounds 2 and 3 (each within the scatter of the next); then compound 1.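

In this assay, ((4-fluorophenyl)sulfonyl)amino in place of (((3-fluorophenyl)sulfonyl)amino)methyl gives a 1.7-fold higher number from compound 2 to compound 3 (0.23 log units; within the scatter) and so stays within the usual scatter, even though the group loses one carbon and its fluorine changes position. The advantage over the six-membered non-aromatic ring of compound 1 also survives with this smaller group, as a 2.9-fold lower number from compound 1 to compound 3 (0.46 log units; beyond the scatter) shows, so it does not depend on the (((3-fluorophenyl)sulfonyl)amino)methyl group alone. No measurement shown here explains these numbers.

Since the chain length and the fluorine position change together in this step, their separate contributions cannot be told apart. As far as these compounds go, it also remains open how a longer chain, or a simple amine or carboxylic acid in place of the sulfonylamino group, would behave at this position.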